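The compounds below may be only part of what the source reports. "The series", "measured", "known", "first", "only" and "open" are said of these compounds alone.

Measured in a functional assay on COLO 320 cells (Homo sapiens) for cytotoxicity, read by MTT assay, with a stated time of 4 h (a higher number here means a weaker inhibitor, a lower number a stronger inhibitor), so far:
Compound 1 `COC(=O)C1=CO[C@@H](O[C@@H]2O[C@H](COC(c3ccccc3)(c3ccccc3)c3ccccc3)[C@@H](O)[C@H](O)[C@H]2O)[C@@H]2[C@@H](C)[C@@H](O)C[C@H]12` gives 0.25 ug/mL
Compound 2 `COC(=O)C1=CO[C@@H](O[C@@H]2O[C@H](COC(c3ccccc3)(c3ccccc3)c3ccccc3)[C@@H](OC(=O)O)[C@H](OC(C)=O)[C@H]2OC(C)=O)[C@@H]2[C@@H](C)[C@@H](OC(C)=O)C[C@H]12` gives 0.82 ug/mL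
Compound 3 `CCC(=O)OC[C@H]1O[C@@H](O[C@@H]2OC=C(C(=O)OC)[C@H]3C[C@H](OC(C)=O)[C@H](C)[C@@H]23)[C@H](OC(C)=O)[C@@H](OC(C)=O)[C@@H]1OC(C)=O` gives 0.85 ug/mL

Compound 2 and compound 3 cannot be told apart, as their numbers lie within the usual scatter. Compound 3 at 0.85 ug/mL does have a higher number than compound 1, and that gap lies beyond the scatter, so compound 3 is the weaker inhibitor of that pair.

Compound 4 `CCCCCCCCCCCCCC(=O)OC[C@H]1O[C@@H](O[C@@H]2OC=C(C(=O)OC)[C@H]3C[C@H](OC(C)=O)[C@H](C)[C@@H]23)[C@H](OC(C)=O)[C@@H](OC(C)=O)[C@@H]1OC(C)=O` differs from compound 3 in one place: undecyl in place of hydrogen on a saturated chain carbon, two bonds along the chain from a carbonyl carbon. This puts undecyl in place of hydrogen on a saturated chain carbon, two bonds along the chain from a carbonyl carbon. For the measured compounds named here, no two measured compounds differ in just one place, so the data offer no direct guide to this change. In this assay no shift beyond the scatter is therefore expected, with only a slight lean towards a higher number. The expected change is a 1.2-fold higher number from compound 3 to compound 4 (0.07 log units; within the scatter) in this estimate. For compound 4 the estimated value is 1 ug/mL within an expected range of 0.3 ug/mL to 3.5 ug/mL in this test.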

Compound 4, half-maximal inhibitory concentration: 30 ug/mL
Beside the measured number, compound 4's estimate is 30-fold (1.48 log units) below it, and the stated range ends below it.
By their numbers in this assay, from the lowest: compound 1; then compounds 2 and 3 (each within the scatter of the next); then compound 4.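

In this assay, the change of undecyl in place of hydrogen on a saturated chain carbon, two bonds along the chain from a carbonyl carbon, gives a 35-fold higher number from compound 3 to compound 4 (1.55 log units; beyond the scatter). For the compounds shown here, this is the first step here between compounds that differ in one place, and it shows that this position is not neutral: a change to this chain alone can move the number a long way towards weaker inhibition. Nothing measured here bears on why the shift is so large.

From the compounds shown here alone, a single step gives only two points, so it remains open whether a hexyl or octyl group in place of undecyl would give a number closer to compound 3 or to compound 4. Going by these compounds, how an amine or a carboxylic acid would behave in place of undecyl also remains open.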